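The source may report more compounds than this note shows. Statements on the series, on what has been measured and on what is new or still open speak of the compounds shown alone.

The three measured compounds were tested in a functional assay on A549 cells (Homo sapiens) for cytotoxicity, read by MTT assay, with a stated time of 72 h; a lower number here means a stronger inhibitor, a higher number a weaker inhibitor. Compound 1 `CN1CCN(CCCCCCn2c3c(c4ccccc42)C(=O)c2c[n+]([O-])c4ccccc4c2C3=O)CC1` gives 330 nM in this assay, and compound 2 `CN1CCN(CCCCCn2c3c(c4ccccc42)C(=O)c2c[n+]([O-])c4ccccc4c2C3=O)CC1` gives 870 nM. Among the measured compounds shown here, the single change from one to the other, 4-methylpiperazin-1-yl in place of (4-methylpiperazin-1-yl)methyl on a saturated chain carbon, five bonds along the chain from an aromatic nitrogen, produced a 2.6-fold higher number from compound 1 to compound 2 (0.42 log units; beyond the scatter). Compound 3 `O=C1c2c[n+]([O-])c3ccccc3c2C(=O)c2c1c1ccccc1n2Cc1cn([C@H]2C[C@H](O)[C@@H](CO)O2)nn1` gives 350 nM in this assay and stands second highest of the three numbers: its value and that of compound 1 lie within the scatter of each other, while compound 2 shows a higher number beyond the scatter.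

Compound 4 `O=C1c2c[n+]([O-])c3ccccc3c2C(=O)c2c1c1ccccc1n2Cc1cn(C[C@@H](O)CO)nn1` differs from compound 3 in one place: 2,3-dihydroxypropyl in place of 4-hydroxy-5-(hydroxymethyl)oxolan-2-yl on an aromatic nitrogen. For the measured compounds named here, no measured step concerns this part of the molecule. Going by the values given here, the only step in the set alters a chain on a different substituent of the shared core and offers no guide to a change on the aromatic nitrogen of the five-membered aromatic ring with 3 nitrogen. With nothing to point either way, the estimated step is a 1.1-fold higher number from compound 3 to compound 4 (0.06 log units; within the scatter), a change expected to stay within the scatter. Compound 4 is therefore expected to give about 400 nM in this assay, with a range from 150 nM to 1100 nM.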

Compound 4, half-maximal inhibitory concentration: 390 nM
Beside the measured number, compound 4's estimate is 1.0-fold (0.01 log units) above it; measured number inside the range.
By their numbers in this assay, from the lowest: compounds 1, 3 and 4 (each within the scatter of the next); then compound 2.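

In this assay, the step at the aromatic nitrogen of the five-membered aromatic ring with 3 nitrogen is a 1.1-fold higher number from compound 3 to compound 4 (0.05 log units; within the scatter), so at this position the five-membered non-aromatic ring of 4-hydroxy-5-(hydroxymethyl)oxolan-2-yl gave way to the open 2,3-dihydroxypropyl chain, with three defined stereocentres reduced to one, and the number stayed within the scatter. Set against the chains ending in 4-methylpiperazin-1-yl, the side chain of compound 4 gives a 2.2-fold lower number from compound 2 to compound 4 (0.35 log units; beyond the scatter) against the butyl-linked group of the shorter chain and a 1.2-fold higher number from compound 1 to compound 4 (0.07 log units; within the scatter) against the pentyl-linked group of the longer one, so a side chain with no 4-methylpiperazin-1-yl group matches the longer of these chains and lies beyond the scatter of the shorter. Nothing available explains these results.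

The compounds shown leave open whether a shorter 2-hydroxyethyl chain, an amine or a carboxylic acid on this aromatic nitrogen would also hold the number in this assay. They also leave open whether the opposite configuration at the single stereocentre of 2,3-dihydroxypropyl would give a different number.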